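A few compounds are considered here, and "the series" means these few. Any claim that something is new, unique, unknown or untested is made for them only; others in the source may bear on it.

The compounds measured so far, with their values in an ADME assay on MDBK cells (Bos taurus) for cytotoxicity, read by MTT assay, with a stated time of 96 h; a lower number here means that less compound is tolerated, a higher number that more compound is tolerated:

compound 1, `CC(=O)Nc1ccc(-c2nc3ccccc3[nH]2)cc1`, > 100000 nM
compound 2, `O=C(CCl)Nc1ccc(-c2nc3cc(C(F)(F)F)ccc3[nH]2)cc1`, 17000 nM
compound 3, `CC(=O)Nc1ccc(-c2nc3cc(C(F)(F)F)ccc3[nH]2)cc1`, 50000 nM.

The entry for compound 1, > 100000 nM, is a limit of this assay, not a measured number. Among the two real numbers, compound 3 stands highest, meaning the most compound is tolerated; its nearest neighbour is compound 2, with a 2.9-fold higher number from compound 2 to compound 3 (0.47 log units; beyond the scatter), a modest step brought about by hydrogen in place of chloro on a saturated chain carbon bound to a carbonyl carbon. The remaining value is the limit (the limit of > 100000 nM in this assay, at which 1 of the 3 values shown sits), and the comparison with compound 3 is an at least 2.0-fold lower number from compound 1 to compound 3 (0.30 log units; that floor lies within the scatter), whose floor lies within the scatter.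

Compound 4, `CC(=O)Nc1ccc(-c2nc3cc([N+](=O)[O-])ccc3[nH]2)cc1`, is the next compound. Its change from compound 3 is nitro in place of trifluoromethyl on an aromatic carbon. Neither measured step exchanges the trifluoromethyl for another group: one adds the trifluoromethyl, the other alters the chain. There is thus no direct guide, and no step beyond the scatter is expected; the estimated step is no change at the digits printed from compound 3 to compound 4 (within the scatter).

Compound 4 is therefore expected to give 50000 nM, with a range from 17000 nM to 100000 nM.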

Compound 4, half-maximal cytotoxic concentration: > 100000 nM
Compound 4 was reported as a limit; the forecaster's own chance of this, stated with the estimate: 25%; at least 2.0-fold (0.30 log units) between middle value and limit.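

In this assay the entry for compound 4, > 100000 nM, is a limit of the assay and not a number. Nitro is a third group on this aromatic carbon, after hydrogen and trifluoromethyl, and exchanging it for trifluoromethyl gives an at least 2.0-fold higher number from compound 3 to compound 4 (0.30 log units; that floor lies within the scatter), so the change did not bring the number down, although a floor of that size does not by itself establish a real difference between the two groups. Nitro and hydrogen on this carbon cannot be told apart, and the step between the two compounds that carry them cannot be read, because both entries are limits: the limit of > 100000 nM in this assay, at which 2 of the 4 values shown sit.

Going by these compounds, how much compound is tolerated with nitro on this carbon remains unknown, and so does the true size of the difference from trifluoromethyl, which would need a number in place of the limit. Also open, on these data alone, are how an amine or a carboxylic acid on the same carbon would read in this assay, and whether the chloro on the chain of compound 2 would lower the number when nitro sits on the core.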